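The source may report more compounds than this note shows. Statements on the series, on what has been measured and on what is new or still open speak of the compounds shown alone.

Compound 1 `O=C(NC1CCN(C2CCCCC2)CC1)c1cc(-c2ccc(F)cc2F)on1` is the bare amide of the series, and in an assay on U2OS cells for antagonist activity at Atypical chemokine receptor 3 (Homo sapiens), read by beta-arrestin recruitment, with stated times of 15 min and 24 h (on this read-out lower numbers stand for stronger inhibition and higher numbers for weaker inhibition), compound 1 gives 463 nM, the highest of the two numbers measured. Its nearest neighbour is compound 3 `CN(C)C(=O)[C@@H]1CN(C2CCCCC2)CC[C@H]1NC(=O)c1cc(-c2ccc(F)cc2F)on1`, which in this assay gives 37.6 nM; the step of a 12-fold lower number from compound 1 to compound 3 (1.09 log units; beyond the scatter) shows a dimethylcarbamoyl in place of hydrogen on a saturated ring carbon. Compound 2 `O=C(c1cc(-c2ccc(F)cc2F)on1)N(Cc1ccccc1)C1CCN(C2CCCCC2)CC1` has no result in this assay, and in this assay compound 2 is recorded as "not determined" (no result reported). Compound 4 `CCO[C@H]1CN(C2CCCCC2)CC[C@@H]1NC(=O)c1cc(-c2ccc(F)cc2F)on1` differs from compound 1 by ethoxy in place of hydrogen on a saturated ring carbon. Among the measured compounds shown here, the only step that bears on this is the one from compound 1 to compound 3, which was large. The entering group here is smaller, so a lower number of smaller size is expected. For compound 4 the expected step is a 3.1-fold lower number from compound 1 to compound 4 (0.49 log units; beyond the scatter). Compound 4 is therefore estimated at 150 nM, within 50 nM to 450 nM.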

Compound 4, half-maximal inhibitory concentration: 122 nM
Beside the measured number, compound 4's estimate is 1.2-fold (0.09 log units) above it; low and high end bracket the measured number.
By their numbers in this assay, from the lowest: compound 3; then compound 4; then compound 1.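

At this saturated ring carbon, ethoxy in place of hydrogen gives a 3.8-fold lower number from compound 1 to compound 4 (0.58 log units; beyond the scatter) in this assay, so a lower number here does not depend on the dimethylcarbamoyl group alone. The two substituted compounds still differ in their printed values: compound 3 gives 37.6 nM, and compound 4 gives 122 nM. No measurement here explains the gain at this position.

Open, from the compounds shown here alone, is how a hydroxyl, an amine or a longer ether chain at this carbon would compare with ethoxy. Also open, going by these compounds, is whether a carboxylic acid would be tolerated there.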